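Linker swap on the shared core: compound 3 to compound 4

The source may hold more compounds than are shown below. What is called first, only, known or untested is meant among the compounds shown, and "the series" means these compounds.

Compound 3 `CCCCCCCCOc1cc(-c2ccccc2)c(-c2ccccc2)nn1` gives 104000 nM in an assay on microsomes from liver for inhibition of sterol O-acyltransferase 1 (Rattus norvegicus) (on this read-out lower numbers stand for stronger inhibition and higher numbers for weaker inhibition), and stands highest of the three numbers, yet both neighbours lie within the scatter of it: compound 2 `CCCCCCCOc1cc(-c2ccccc2)c(-c2ccccc2)nn1` gives 58000 nM and compound 1 `CCCCCCCNc1cc(-c2ccccc2)c(-c2ccccc2)nn1` gives 55000 nM. Compound 4 `CCCCCC[S+]([O-])c1cc(-c2ccccc2)c(-c2ccccc2)nn1` is the unmeasured member; the change from compound 3 is a group of 8 heavy atoms (6 carbon, 1 oxygen, 1 sulfur; no ring) in place of a group of 9 heavy atoms (8 carbon, 1 oxygen; no ring), on an aromatic carbon. Among the measured compounds shown here, two measured steps bear on it. Exchanging the linker atom, heptyloxy in place of heptylamino, gave a 1.1-fold higher number from compound 1 to compound 2 (0.02 log units; within the scatter); lengthening the chain gave a 1.8-fold higher number from compound 2 to compound 3 (0.25 log units; within the scatter). Both sit within the scatter, so compound 4 is expected to show no step beyond the scatter in this assay, a 1.3-fold lower number from compound 3 to compound 4 (0.11 log units; within the scatter). The estimate for compound 4 is 80000 nM, with a range from 30000 nM to 200000 nM.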

Compound 4, half-maximal inhibitory concentration: 75000 nM
Estimate against measurement, compound 4: 1.1-fold (0.03 log units) above, and the stated range covers the measured number.
By their numbers in this assay, from the lowest: compounds 1, 2, 4 and 3 (each within the scatter of the next).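

Exchanging the linker at this aromatic carbon has still produced no step beyond the scatter in this assay, now with a group holding sulfur and oxygen on the shared core (a 1.4-fold lower number from compound 3 to compound 4 (0.14 log units; within the scatter)). The same holds against the other two linkers (a 1.3-fold higher number from compound 2 to compound 4 (0.11 log units; within the scatter); a 1.4-fold higher number from compound 1 to compound 4 (0.13 log units; within the scatter)), so the four compounds form one band with no order among them. No measured evidence accounts for this flat result.

From the compounds shown here alone, whether a longer chain or a carboxylic acid at the chain end would move the number beyond the scatter remains open. Also open, going by these compounds, is how a plain sulfur linker, without the oxygen, would compare with compound 4.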